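The source may report more compounds than this note shows. Statements on the series, on what has been measured and on what is new or still open speak of the compounds shown alone.

Measured so far in a functional assay on LNCaP cells (Homo sapiens) for cytotoxicity; a higher number here means that more compound is needed for the effect, a lower number that less compound is needed:
compound 1, `CCCCCCC(=O)C(Br)=C(Br)Br`, gives > 20 ug/mL
compound 2, `CCCCC1=C(Br)/C(=C/Br)OC1=O`, gives 7.3 ug/mL
compound 3, `CCCCC1=C(Br)C(=C(Br)Br)OC1=O`, gives 9.3 ug/mL.

For compound 1 the value in this assay is a limit of the assay and not a number (the limit of > 20 ug/mL in this assay, at which 1 of the 3 values shown sits). Among the two numbers, compound 2 gives the lowest; the number for compound 3 lies within the scatter of it, so the two cannot be told apart on the data. Both of these share the lactone-bearing core shown in their structures and differ from compound 1 in having it.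

Compound 4, `CCC[C@@H](O)C1=C(Br)/C(=C/Br)OC1=O`, has not yet been measured in this assay. It differs from compound 2 in one place: hydroxy in place of hydrogen on a saturated chain carbon bound to a double-bonded ring carbon and a saturated chain carbon. Going by the values given here, none of the measured compounds carries this change, so no measured step bears directly on it. The step from compound 2 to compound 4 in this assay is expected to be small, a 1.4-fold higher number from compound 2 to compound 4 (0.14 log units; within the scatter), with a slight lean toward a larger number but not beyond the scatter. For compound 4 the estimated value in this assay is 10 ug/mL, with a range from 4.5 ug/mL to 22 ug/mL.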

Compound 4, concentration for half-maximal effect: 0.2 ug/mL
Compound 4: middle estimate off by 50-fold (1.70 log units), on the high side; the measured number lies below the stated range.
By their numbers in this assay, from the lowest: compound 4; then compounds 2 and 3 (each within the scatter of the next). At a limit, above all of these: compound 1.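

In this assay, the saturated chain carbon bound to a double-bonded ring carbon and a saturated chain carbon turns out to be a sensitive position: hydroxy in place of hydrogen there gives a 37-fold lower number from compound 2 to compound 4 (1.56 log units; beyond the scatter). The earlier compounds carry only hydrogen on the corresponding chain carbon, so they gave no indication that a change at this position could matter, and this single added group now accounts for a step well beyond the scatter. The data shown offer no measured property that would explain the size of this step.

As far as these compounds go, it remains open whether the lower number depends on hydroxy itself or would also appear with a methoxy group, an amine or a fluorine on the same carbon, and whether the opposite configuration at this carbon would give a similar number. From the compounds shown here alone, it is equally open whether hydroxy at this position would have a comparable effect in the dibromomethylidene compound 3, or on a longer chain, since a single step on one parent compound cannot show how far the effect carries.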